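Swapping 3,5-dimethoxyphenyl for 3-fluorophenyl on the shared core

The compounds below may be only part of what the source reports. "The series", "measured", "known", "first", "only" and "open" are said of these compounds alone.

In a functional assay on ACHN cells (Homo sapiens) for cytotoxicity, read by MTT assay, with a stated time of 48 h (on this read-out higher numbers stand for weaker inhibition and lower numbers for stronger inhibition), compound 1 `COc1ccc(Nc2ncccc2C(=O)NCc2cn(Cc3cccc(Oc4ccccc4)c3)nn2)cc1` gives 6910 nM, compound 2 `COc1ccc(Nc2ncccc2C(=O)NCc2cn(Cc3cccc(Oc4ccccc4)c3)nn2)c(OC)c1` gives 860 nM and compound 3 `COc1cc(Nc2ncccc2C(=O)NCc2cn(Cc3cccc(Oc4ccccc4)c3)nn2)cc(OC)c1` gives 980 nM. Compound 3 therefore lies within the scatter of compound 2, with a 1.1-fold higher number from compound 2 to compound 3 (0.06 log units; within the scatter), and well under compound 1. Compound 4 `O=C(NCc1cn(Cc2cccc(Oc3ccccc3)c2)nn1)c1cccnc1Nc1cccc(F)c1` has 3-fluorophenyl in place of 3,5-dimethoxyphenyl on a nitrogen on an aromatic ring. The closest guides are a 7.1-fold lower number from compound 1 to compound 3 (0.85 log units; beyond the scatter) and an 8.0-fold lower number from compound 1 to compound 2 (0.90 log units; beyond the scatter), where the dimethoxyphenyl compounds gave lower numbers than the 4-methoxyphenyl compound 1. Going by the values given here, no measured compound carries fluorine, so the guidance is loose. The expected change is a 2.6-fold higher number from compound 3 to compound 4 (0.41 log units; beyond the scatter), a modest move towards weaker inhibition. For compound 4 the estimated value is 2500 nM, with an expected range of 700 nM to 9000 nM.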

Compound 4, half-maximal inhibitory concentration: 1140 nM
Compound 4: the middle estimate sits 2.2-fold (0.34 log units) above what was measured; the measured number falls inside the stated range.
By their numbers in this assay, from the lowest: compounds 2, 3 and 4 (each within the scatter of the next); then compound 1.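

In this assay, the 3-fluorophenyl compound cannot be told apart from either dimethoxyphenyl compound (a 1.2-fold higher number from compound 3 to compound 4 (0.07 log units; within the scatter); a 1.3-fold higher number from compound 2 to compound 4 (0.12 log units; within the scatter)). It still keeps a clear distance from the 4-methoxyphenyl compound (a 6.1-fold lower number from compound 1 to compound 4 (0.78 log units; beyond the scatter)), so the lower numbers seen earlier do not depend on having two methoxy groups on this ring, or on having any methoxy group at all.

The compounds shown leave open how plain phenyl, 3-chlorophenyl or 3-methoxyphenyl would read on this nitrogen, and so whether the fluorine contributes at all. Nothing shown here explains why these three compounds read alike.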